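A Chloro Group Enters the Second Phenyl Ring

The source may hold more compounds than are shown below. What is called first, only, known or untested is meant among the compounds shown, and "the series" means these compounds.

Measured so far:
compound 1 `O=C(Nc1nc2ccc(F)cc2s1)c1cn(-c2ccccc2)nc1-c1ccccc1`: 3250 nM
compound 2 `Cc1ccc2nc(NC(=O)c3cn(-c4ccccc4)nc3-c3ccccc3)sc2c1`: 15700 nM

In a functional assay on PC-3 cells (Homo sapiens) for cytotoxicity, read by MTT assay, with a stated time of 72 h (a higher number here means a weaker inhibitor, a lower number a stronger inhibitor), compound 1 gives 3250 nM, and compound 2 gives 15700 nM. Compound 2 thus holds the higher of the two numbers, set apart from compound 1 by the step of a 4.8-fold higher number from compound 1 to compound 2 (0.68 log units; beyond the scatter). Compound 3 `Cc1ccc2nc(NC(=O)c3cn(-c4ccccc4)nc3-c3ccc(Cl)cc3)sc2c1` differs from compound 2 by chloro in place of hydrogen on an aromatic carbon. Going by the values given here, the one measured step concerns a different ring, so no measured step bears directly on this change. Compound 3 is therefore expected to stay close to compound 2, with an estimated step of a 1.2-fold lower number from compound 2 to compound 3 (0.08 log units; within the scatter) that lies within the scatter. Compound 3 is estimated at 13000 nM, in a range from 4500 nM to 40000 nM.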

Compound 3, half-maximal inhibitory concentration: 14500 nM
Compound 3: the middle estimate sits 1.1-fold (0.05 log units) below what was measured; the range from low to high includes it.
By their numbers in this assay, from the lowest: compound 1; then compounds 3 and 2 (each within the scatter of the next).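

In this assay, phenyl to 4-chlorophenyl gives a 1.1-fold lower number from compound 2 to compound 3 (0.03 log units; within the scatter), so compound 3 and compound 2 cannot be told apart. Going by these compounds alone, this is the first reading at this ring, and a chloro here, para to a large group, leaves the number within the scatter, unlike the methyl-for-fluoro step elsewhere in the molecule. No available evidence bears on this result.

As far as these compounds go, whether an amine or a carboxylic acid at this position would read the same remains open. So does whether chloro would behave alike on compound 1.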